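A few compounds are considered here, and "the series" means these few. Any claim that something is new, unique, unknown or untested is made for them only; others in the source may bear on it.

Compound 1 `CCNC(=O)Nc1c(OCCCn2cnc(-c3ccccc3)c2)cccc1N(C)C`: 870 nM in an assay for inhibition of acyl-CoA:cholesterol acyltransferase (Oryctolagus cuniculus), using microsomes; a higher number here means a weaker inhibitor, a lower number a stronger inhibitor
Compound 2 `CCCNC(=O)Nc1c(OCCCn2cnc(-c3ccccc3)c2)cccc1N(C)C`: 660 nM in this assay
Compound 3 `CCCCCNC(=O)Nc1c(OCCCn2cnc(-c3ccccc3)c2)cccc1N(C)C`: 31 nM in this assay

Compound 3 gives the lowest number of the three in this assay, and its steps to compound 2 and to compound 1 both lie beyond the scatter, so it stands as the strongest inhibitor among the measured set. Compound 4 `CCCCCCNc1c(OCCCn2cnc(-c3ccccc3)c2)cccc1N(C)C` differs from compound 3 in one place: hexyl in place of pentylcarbamoyl on a nitrogen on an aromatic ring. The measured steps all concern the chain on the carbamoyl nitrogen: a 1.3-fold lower number from compound 1 to compound 2 (0.12 log units; within the scatter), a 28-fold lower number from compound 1 to compound 3 (1.45 log units; beyond the scatter) and a 21-fold lower number from compound 2 to compound 3 (1.33 log units; beyond the scatter). The two larger steps show that a longer chain brings a lower number, while the step from compound 1 to compound 2 lies within the scatter. None of these steps removes the carbamoyl group itself, which is what the change to compound 4 does, so the bearing of the measured steps on it is only indirect. Compound 4 is therefore expected to show a 9.7-fold higher number from compound 3 to compound 4 (0.99 log units; beyond the scatter), an estimated 300 nM with a range from 30 nM to 3000 nM.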

Compound 4, half-maximal inhibitory concentration: 11000 nM
Compound 4: the middle estimate sits 37-fold (1.56 log units) below what was measured; measured number outside the range, above it.
By their numbers in this assay, from the lowest: compound 3; then compounds 2 and 1 (each within the scatter of the next); then compound 4.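

In this assay, going by these compounds alone, hexyl in place of pentylcarbamoyl on the nitrogen on an aromatic ring gives a 350-fold higher number from compound 3 to compound 4 (2.55 log units; beyond the scatter) and so costs far more than any step in chain length among the earlier compounds. The long chain does not hold the gain on its own, as the change also gives a 17-fold higher number from compound 2 to compound 4 (1.22 log units; beyond the scatter) and a 13-fold higher number from compound 1 to compound 4 (1.10 log units; beyond the scatter) even though those two compounds carry only propyl and ethyl chains on the carbamoyl nitrogen. At this position, then, the carbamoyl group matters at least as much as the chain it carries. The compounds shown leave open whether the carbonyl or the amide hydrogen accounts for the loss, which an amide or a carbamate at this nitrogen could separate, and how a longer chain on the carbamoyl nitrogen would fare. Nothing measured here explains the size of this change.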